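The compounds below may be only part of what the source reports. "The series", "measured", "known", "first", "only" and "open" are said of these compounds alone.

Compound 1 `NC(=S)N/N=C/c1ccc2ccccc2n1` and compound 2 `Fc1cccc(NC(=S)N/N=C/c2ccc3ccccc3n2)c1` share a thiosemicarbazone core bearing the same aromatic bicyclic aldehyde fragment, and they differ only at the amide-type nitrogen. In a functional assay on HL-60 cells (Homo sapiens) for antiproliferative activity, read by sulforhodamine B assay, with a stated time of 72 h (on this read-out lower numbers stand for stronger inhibition and higher numbers for weaker inhibition), compound 1 gives > 100000 nM, which is a limit of the assay rather than a number (the limit of > 100000 nM in this assay, at which 1 of the 2 values shown sits). In this assay compound 2 gives 43800 nM, the only number shown among the two, so it stands alone as the single quantified point. Among the compounds with values here, the one measured step, an at least 2.2-fold lower number from compound 1 to compound 2 (0.35 log units; beyond the scatter), therefore shows that placing a 3-fluorophenyl on the amide-type nitrogen moves the compound from a limit to a measurable value.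

Compound 3 `S=C(N/N=C/c1ccc2ccccc2n1)Nc1cccc(Cl)c1` is not yet measured. It differs from compound 2 by chloro in place of fluoro on an aromatic carbon. Within the data shown here, no measured step bears directly on exchanging one halogen for another on that ring; the only step available concerns adding the whole 3-fluorophenyl. He therefore expects at most a small movement, likely within the scatter, with no firm direction. He estimates that compound 3 will give 30000 nM in this assay, between 10000 nM and 90000 nM, which corresponds to an expected step of a 1.5-fold lower number from compound 2 to compound 3 (0.16 log units; within the scatter).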

Compound 3, half-maximal inhibitory concentration: 28800 nM
Estimate against measurement, compound 3: 1.0-fold (0.02 log units) above, within the range that was stated.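

In this assay, chloro in place of fluoro on an aromatic carbon, meta to a large group, gives a 1.5-fold lower number from compound 2 to compound 3 (0.18 log units; within the scatter), so the 3-fluorophenyl and 3-chlorophenyl groups cannot be told apart on this read-out. The replacement of hydrogen on the amide-type nitrogen now has a second example, with 3-chlorophenyl giving an at least 3.4-fold lower number from compound 1 to compound 3 (0.54 log units; beyond the scatter), which shows that the earlier move from a limit to a measurable value is not confined to the fluoro compound. Compound 1 stands at a limit of the assay and not at a number, so this step is only a bound and its true size stays unknown: the limit of > 100000 nM in this assay, at which 1 of the 3 values shown sits.

The compounds shown leave open whether a phenyl carrying no halogen would keep this effect, and whether a methoxy, an amine or a carboxylic acid in place of the halogen would shift the value beyond the scatter. They also leave open whether chloro or fluoro elsewhere on the same ring would read as these two do.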